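Nitro to chloro exchange on the exocyclic aryl ring

The source may hold more compounds than are shown below. What is called first, only, known or untested is meant among the compounds shown, and "the series" means these compounds.

Compound 2 `O=C1/C(=C\c2ccccc2[N+](=O)[O-])c2ccccc2N1c1c(Cl)cccc1Cl` is the reference point of the series. Going by the values given here, in a functional assay on MIA PaCa-2 cells (Homo sapiens) for cytotoxicity, read by MTT assay, with a stated time of 72 h (a higher number here means that more compound is needed for the effect, a lower number that less compound is needed), compound 2 gives 5 ug/mL, the only number recorded so far. Compound 1 `O=C1/C(=C\c2c(Cl)cccc2Cl)c2ccccc2N1c1c(Cl)cccc1Cl` reaches only a limit in this assay, > 100 ug/mL (the limit of > 100 ug/mL in this assay, at which 1 of the 2 values shown sits). Among the compounds with values here, the single measured step is an at least 20-fold lower number from compound 1 to compound 2 (1.30 log units; beyond the scatter), leading from a limit to a number.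

Compound 3 `O=C1/C(=C\c2ccccc2Cl)c2ccccc2N1c1c(Cl)cccc1Cl` is not yet measured. Its change from compound 2 is chloro in place of nitro on an aromatic carbon. This partly reverses the measured step: that step also exchanged chloro for nitro, but compound 1 carries a second chloro as well, so the measured step cannot be split cleanly between the two changes. If the nitro-to-chloro exchange alone carried most of that step, compound 3 would move back toward the limit; if the second chloro carried it, compound 3 would stay near compound 2. The expected step is a 3.0-fold higher number from compound 2 to compound 3 (0.48 log units; beyond the scatter), toward a higher number in this assay, with wide uncertainty. Compound 3 is therefore estimated to give 15 ug/mL, within a range from 4 ug/mL to 60 ug/mL.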

Compound 3, concentration for half-maximal effect: > 100 ug/mL
Compound 3 was reported as a limit; the forecaster's own chance of this, stated with the estimate: 15%; middle value at least 6.6-fold (0.82 log units) from the limit.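

Exchanging nitro for chloro on this aromatic carbon, with nothing else in the structure altered, gives an at least 20-fold higher number from compound 2 to compound 3 (1.30 log units; beyond the scatter) in this assay, so this one exchange is enough to leave the measurable range and the second chloro of compound 1 is not needed for that. Compound 3 gives > 100 ug/mL, which is a limit of the assay and not a number. The step between compound 1 and compound 3 cannot be read, so these two compounds show no effect of the second chloro, and among the compounds shown only the 2-nitrophenyl group gives a number: the limit of > 100 ug/mL in this assay, at which 2 of the 3 values shown sit.

From the compounds shown here alone, it remains open whether nitro is singular at this place on the ring or whether a nitrile, a methoxy group or an amine would also give a number in this assay. Going by these compounds, it also remains open whether the number of compound 2 depends on the two chloro groups on the aryl ring attached to the nitrogen of the shared core, as a plain phenyl group there would test.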